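The source may hold more compounds than are shown below. What is called first, only, known or untested is meant among the compounds shown, and "the series" means these compounds.

Measured compounds:
compound 1 `Cc1nn(-c2nc(-c3ccc(Cl)c(Cl)c3)c(SC(C)C)s2)c(C(=O)O)c1-c1cccc(C(F)(F)F)c1`, 22000 nM
compound 2 `Cc1nn(-c2nc(-c3ccc(Cl)c(Cl)c3)c(SC(C)C)s2)c(C(=O)O)c1-c1cccnc1`, 12000 nM

Among the measured compounds shown here, only two compounds have been measured in a functional assay on BJAB cells (Homo sapiens) for antiproliferative activity, with a stated time of 4 days (on this read-out higher numbers stand for an effect only at larger amounts of compound and lower numbers for an effect already at smaller amounts), and compound 2 lies close to compound 1: the single step of a 1.8-fold lower number from compound 1 to compound 2 (0.26 log units; within the scatter) is within the scatter, so the two numbers cannot be told apart.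

Compound 3 `Cc1nn(-c2nc(-c3ccc(Cl)c(Cl)c3)c(SC(C)C)s2)c(C(=O)O)c1-c1ccccc1C(F)(F)F` carries the change (2-(trifluoromethyl)phenyl in place of pyridin-3-yl on an aromatic carbon). For the measured compounds named here, the one step that bears on it is a 1.8-fold lower number from compound 1 to compound 2 (0.26 log units; within the scatter), where 3-(trifluoromethyl)phenyl gave way to pyridin-3-yl without a change beyond the scatter. Going by the values given here, the move to compound 3 goes back to a trifluoromethyl-bearing phenyl ring, now with the trifluoromethyl at the 2-position, for which no measured step exists. Because a 1.8-fold lower number from compound 1 to compound 2 (0.26 log units; within the scatter) was within the scatter, no step beyond the scatter is expected in this assay. Compound 3 is estimated at 18000 nM, between 6000 nM and 50000 nM, an expected step of a 1.5-fold higher number from compound 2 to compound 3 (0.18 log units; within the scatter).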

Compound 3, half-maximal effective concentration: 5200 nM
For compound 3 the middle estimate is 3.5-fold (0.54 log units) above the measured one; the whole stated range lies above it.
By their numbers in this assay, from the lowest: compound 3; then compounds 2 and 1 (each within the scatter of the next).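

In this assay, among the compounds shown here, 2-(trifluoromethyl)phenyl in place of pyridin-3-yl gives a 2.3-fold lower number from compound 2 to compound 3 (0.36 log units; beyond the scatter), the first change on this aromatic carbon that stands clear of the scatter. Shifting the trifluoromethyl group on the phenyl ring, with 2-(trifluoromethyl)phenyl in place of 3-(trifluoromethyl)phenyl, gives a 4.2-fold lower number from compound 1 to compound 3 (0.63 log units; beyond the scatter), so among these three compounds the place of that group on the ring counts, not merely its presence. Both steps are modest, and no accompanying measurement gives a reason for either of them.

Still open, as far as these compounds go, is whether the trifluoromethyl group itself is needed, which 2-methylphenyl, 2-chlorophenyl or plain phenyl on this carbon would help to settle. Also open, from the compounds shown here alone, is how an amine on that phenyl ring, as in 2-aminophenyl, would read in this assay.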